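Phenyl for ethyl on the triazole nitrogen of compound 3

This account rests on a few compounds, and the source may have more. Where it says the series, first, only, none or still open, it means among the compounds named here.

Measured compounds:
compound 1 `C=CCn1c(SCC(=O)c2ccccc2)nnc1-c1ccccc1` — 43%
compound 2 `O/N=C(/CSc1nnc(-c2ccccc2)n1-c1ccccc1)c1ccccc1` — 60%
compound 3 `CCn1c(SCC(=O)c2ccccc2)nnc1-c1ccccc1` — 52%

In a functional assay on the whole organism (strain albino) for inhibition, with Rattus norvegicus as the target, read by paw edema, with a stated time of 1 h, at a dose of 0.28 mmol/kg by the oral route (on this read-out higher numbers stand for more inhibition at the one dose given (going by the name of the read-out) and lower numbers for less inhibition), compound 3 stands second highest of the three numbers; its gaps to compound 2 and to compound 1 both lie within the scatter. Compound 4 `O=C(CSc1nnc(-c2ccccc2)n1-c1ccccc1)c1ccccc1` arises from compound 3 by phenyl in place of ethyl on an aromatic nitrogen. Among the compounds with values here, the only step that changes the group on this aromatic nitrogen is a number 9 percentage points higher from compound 1 to compound 3 (within the scatter), and it stayed within the scatter. Compound 2, which already carries the phenyl on that nitrogen, gives 60%, a number not far from compound 3. The step of a number 3 percentage points higher from compound 3 to compound 4 (within the scatter) is therefore expected to stay within the scatter. Compound 4 is estimated at 55%, in the range 40% to 70%.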

Compound 4, a percentage reported as inhibition, in the whole organism at one dose (the size of the read-out at that dose, not a potency): 53%
Beside the measured number, compound 4's estimate is 2 percentage points above it; low and high end bracket the measured number.
By their numbers in this assay, from the lowest: compounds 1, 3, 4 and 2 (each within the scatter of the next, the first and the last beyond it).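

In this assay, phenyl in place of ethyl on the aromatic nitrogen gives a number 1 percentage points higher from compound 3 to compound 4 (within the scatter), and phenyl in place of allyl there gives a number 10 percentage points higher from compound 1 to compound 4 (within the scatter). This position thus takes a six-membered aromatic ring without a step beyond the scatter from either chain. On the saturated chain carbon bound to a sulfur, the exchange of groups gives a number 7 percentage points lower from compound 2 to compound 4 (within the scatter).

Nothing given here accounts for these numbers. The compounds shown leave open how an amine or a carboxylic acid on that aromatic nitrogen, or a longer chain there, would read out.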